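Solubility Beyond a Limit: Phenoxy Gives Way to Pyridin-3-yl

A few compounds are considered here, and "the series" means these few. Any claim that something is new, unique, unknown or untested is made for them only; others in the source may bear on it.

Measured compounds:
compound 1, `CNC(=O)c1cc(Oc2ccc3nc(Nc4ccc(OC)cc4)ncc3c2)ccn1`, < 1000 nM
compound 2, `CNC(=O)c1cc(Oc2ccc3nc(Nc4ccc(Oc5ccccc5)cc4)ncc3c2)ccn1`, < 1000 nM

In a physicochemical assay for solubility, at pH 7 (on this read-out higher numbers stand for higher solubility and lower numbers for lower solubility), compound 1 gives only a limit, < 1000 nM. In this assay compound 2 likewise gives only a limit, < 1000 nM. Both values sit at the limit of < 1000 nM in this assay, at which 2 of the 2 values shown sit. For the measured compounds named here, the single measured step, a step that the two limits leave unreadable from compound 1 to compound 2, therefore cannot be read in either direction or size, and compound 2 stands at the limit rather than at a known number.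

Compound 3, `CNC(=O)c1cc(Oc2ccc3nc(Nc4ccc(-c5cccnc5)cc4)ncc3c2)ccn1`, differs from compound 2 by pyridin-3-yl in place of phenoxy on an aromatic carbon. Going by the values given here, no measured step bears on this change, since the only step available is unreadable. The expectation for compound 3 thus rests on the limit alone: an estimated 1200 nM in this assay, with a range from 300 nM to 5000 nM. The estimated step of an at least 1.2-fold higher number from compound 2 to compound 3 (0.07 log units; that floor lies within the scatter) is an expectation, not a measurement, and a further limit remains a real possibility.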

Compound 3, solubility: < 1000 nM
Compound 3 ended at the assay's limit; the forecaster's own chance of this, stated with the estimate: 55%; middle value at least 1.2-fold (0.07 log units) from the limit.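

In this assay compound 3 gives < 1000 nM, which is a limit and not a number. Its steps from compound 1 and from compound 2 therefore cannot be read: the limit of < 1000 nM in this assay, at which 3 of the 3 values shown sit.

On these data alone, whether compound 1, compound 2 and compound 3 differ at all in solubility, and by how much, stays open.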